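Aryl substituent exchange: compound 2 to compound 3

A few compounds are considered here, and "the series" means these few. Any claim that something is new, unique, unknown or untested is made for them only; others in the source may bear on it.

Measured so far:
compound 1, `COc1ccc(N2C[C@@H](C)N[C@@H](C)C2)cc1NS(=O)(=O)c1ccc(N2CCCC2=O)cc1`, 0.8
compound 2, `COc1ccc(N2C[C@@H](C)N[C@@H](C)C2)cc1NS(=O)(=O)c1ccc(-n2cccn2)cc1`, 0.8

Both values come from a functional assay for agonist activity at growth hormone secretagogue receptor type 1 (Homo sapiens), read by FLIPR; on this read-out higher numbers stand for larger maximal responses and lower numbers for smaller maximal responses. Going by the values given here, the one measured step, no change at the digits printed from compound 1 to compound 2 (within the scatter), swaps one five-membered aromatic group for another on an aromatic carbon and leaves the maximal response where it was. Compound 2 thus stands level with compound 1 at the digits shown; nothing in the series so far lies beyond the scatter.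

Compound 3, `COc1ccc(N2C[C@@H](C)N[C@@H](C)C2)cc1NS(=O)(=O)c1ccc(-c2ccc(C)o2)cc1`, is not yet measured. Its difference from compound 2 is 5-methylfuran-2-yl in place of 1H-pyrazol-1-yl on an aromatic carbon. Among the compounds with values here, this is again an exchange of one five-membered aromatic group for another on an aromatic carbon, and the only step that bears on it, no change at the digits printed from compound 1 to compound 2 (within the scatter), was flat. No step beyond the scatter is therefore expected in this assay, in either direction. Compound 3 is expected to give an intrinsic activity near 0.8, within 0.6 to 1. The implied step is expected to be no change at the digits printed from compound 2 to compound 3 (within the scatter).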

Compound 3, intrinsic activity: the largest response reached, as a fraction of the reference agonist's: 1
Beside the measured number, compound 3's estimate is 0.20 below it, and the stated range covers the measured number.
By their numbers in this assay, from the lowest: compounds 1 and 2 (each within the scatter of the next); then compound 3.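

At the aromatic carbon para to a large group, the maximal response in this assay does depend on the substituent: 5-methylfuran-2-yl in place of 1H-pyrazol-1-yl gives a number 0.20 higher from compound 2 to compound 3 (beyond the scatter), and 5-methylfuran-2-yl in place of 2-oxopyrrolidin-1-yl gives a number 0.20 higher from compound 1 to compound 3 (beyond the scatter). The position had looked flat on the earlier exchange alone, no change at the digits printed from compound 1 to compound 2 (within the scatter), whereas compound 3 now stands clear of both other compounds as the highest of the three. No measurement available here bears on why the 5-methylfuran-2-yl group gives this rise.

The compounds shown leave open whether the gain belongs to the furan ring or to its methyl group, a question that plain furan-2-yl would address. On these data alone, it is also open whether a thiophen-2-yl or a phenyl group at this position would hold the response of compound 3.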